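This account rests on a few compounds, and the source may have more. Where it says the series, first, only, none or still open, it means among the compounds named here.

Compound 1 `CNC(=O)c1cc(Oc2ccc(C3=NNC(c4ccc(F)cc4)C3)cc2)ccn1` and compound 2 `CNC(=O)c1cc(Oc2ccc(C3CC(c4ccc([N+](=O)[O-])cc4)=NN3)cc2)ccn1` share a core whose difference is not broken down here. In a functional assay on HepG2 cells (Homo sapiens) for cytotoxicity, read by MTT assay, with a stated time of 72 h (on this read-out lower numbers stand for stronger inhibition and higher numbers for weaker inhibition), compound 1 gives 5280 nM, while compound 2 gives 28900 nM. Compound 3 `CNC(=O)c1cc(Oc2ccc(C3=NN(C(N)=S)C(c4ccc(F)cc4)C3)cc2)ccn1` carries a group of 3 heavy atoms (1 carbon, 1 nitrogen, 1 sulfur; no ring) in place of a hydrogen atom, on an amine nitrogen in a ring; in this assay compound 3 reaches only a limit of the assay, > 50000 nM, namely (the limit of > 50000 nM in this assay, at which 1 of the 3 values shown sits). That gives an at least 9.4-fold higher number from compound 1 to compound 3 (0.97 log units; beyond the scatter). Compound 4 `CNC(=O)c1cc(Oc2ccc(C3CC(c4ccc([N+](=O)[O-])cc4)=NN3C(N)=S)cc2)ccn1` carries the same kind of change, (a group of 3 heavy atoms (1 carbon, 1 nitrogen, 1 sulfur; no ring) in place of a hydrogen atom, on an amine nitrogen in a ring), here next to the ring atom that bears a large group and two ring bonds from the ring atom that bears a 4-nitrophenyl group. From compound 2 to compound 4 a step like the earlier one is expected, a 5.2-fold higher number from compound 2 to compound 4 (0.72 log units; beyond the scatter), resting on compound 2 at 28900 nM and the step of an at least 9.4-fold higher number from compound 1 to compound 3 (0.97 log units; beyond the scatter). Compound 4 is therefore estimated at 150000 nM, between 40000 nM and 500000 nM.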

Compound 4, half-maximal inhibitory concentration: > 50000 nM
Compound 4: no number, only a limit (the forecaster's own chance of this, stated with the estimate: 75%); the middle value does not contradict the limit.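

In this assay compound 4 gives no number, only a limit, > 50000 nM. Read as a floor, this gives an at least 1.7-fold higher number from compound 2 to compound 4 (0.23 log units; that floor lies within the scatter), so on both cores the added group moves the read-out towards higher numbers, and the two steps can be set side by side: the same change on two cores in this assay, an at least 9.4-fold higher number (0.97 log units; beyond the scatter) from compound 1 to compound 3 and an at least 1.7-fold higher number (0.23 log units; that floor lies within the scatter) from compound 2 to compound 4; the limit leaves it open whether they differ. This shows that the change brought no stronger inhibition on either core, but it does not show the true size of either step, or whether the change carries over to the second core with the same size.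

The compounds shown leave open how an amine, a carboxylic acid or a longer chain would read in this assay if placed on that amine nitrogen in the ring.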